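A few compounds are considered here, and "the series" means these few. Any claim that something is new, unique, unknown or untested is made for them only; others in the source may bear on it.

In a functional assay on HL-60 cells (Homo sapiens) for cytotoxicity, read by luminescence and CellTiter-Glo, with a stated time of 3 days (a higher number here means a weaker inhibitor, a lower number a stronger inhibitor), compound 1 `Cc1ccc(C(=O)Nc2ccc(C#N)cc2)c(O)c1` gives 2420 nM and compound 2 `N#Cc1ccc(NC(=O)c2ccc(-c3cccnc3)cc2O)cc1` gives 6660 nM as the higher of the two numbers, which makes it the weaker inhibitor of the pair. The change to compound 3 `N#Cc1ccc(NC(=O)c2ccc(-c3ccccc3)cc2O)cc1` is phenyl in place of pyridin-3-yl on an aromatic carbon in a single place, with phenyl in place of pyridin-3-yl on an aromatic carbon. Among the compounds with values here, the only measured step at this place is a 2.8-fold higher number from compound 1 to compound 2 (0.44 log units; beyond the scatter) and it is modest, but it replaces methyl and does not compare two rings. No step beyond the scatter is therefore expected in this assay for this swap. The expected step is a 1.2-fold lower number from compound 2 to compound 3 (0.08 log units; within the scatter) by this estimate. Compound 3 is estimated at 5500 nM with 2500 nM to 12000 nM as the expected range.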

Compound 3, half-maximal inhibitory concentration: 700 nM
Compound 3: the middle estimate sits 7.9-fold (0.90 log units) above what was measured, outside the stated range (below it).
By their numbers in this assay, from the lowest: compound 3; then compound 1; then compound 2.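

In this assay, the group at this position matters. Exchanging pyridin-3-yl for phenyl gives a 9.5-fold lower number from compound 2 to compound 3 (0.98 log units; beyond the scatter) with the ring size unchanged. Against methyl, the two rings move the number in opposite directions: phenyl gives a 3.5-fold lower number from compound 1 to compound 3 (0.54 log units; beyond the scatter) and pyridin-3-yl gives a 2.8-fold higher number from compound 1 to compound 2 (0.44 log units; beyond the scatter) in this series. No measurement at hand explains this gap. Still open, from the compounds shown here alone, is how pyridin-4-yl or a saturated cyclohexyl ring would behave at this position, and whether the phenyl result holds in other cell types.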